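Swapping Trifluoromethyl for Nitro: An Expected Small Step

This account rests on a few compounds, and the source may have more. Where it says the series, first, only, none or still open, it means among the compounds named here.

Of the compounds shown here, two have so far been tested in a functional assay on MCF7 cells (Homo sapiens) for antiproliferative activity, read by MTT assay, with a stated time of 72 h; on this read-out lower numbers stand for stronger inhibition and higher numbers for weaker inhibition. Compound 1 `FC(F)(F)c1ccc(COc2cccc(Nc3ncnc4cc5c(cc34)OCCOCCOCCOCCO5)c2)cc1` gives 8480 nM in this assay, the lower of the two numbers. Compound 2 `FC(F)(F)c1ccc(COc2ccc(Nc3ncnc4cc5c(cc34)OCCOCCOCCO5)cc2)cc1` differs from compound 1 in several places. In this assay compound 2 gives 28500 nM, a number that lies beyond the scatter above that of compound 1. Compound 3 `O=[N+]([O-])c1ccc(COc2cccc(Nc3ncnc4cc5c(cc34)OCCOCCOCCOCCO5)c2)cc1` has not yet been measured. Relative to compound 1 it carries a nitro in place of trifluoromethyl on an aromatic carbon. For the measured compounds named here, no step between measured compounds shows what this exchange does, so the expectation rests on the value of compound 1 alone. Such an exchange is expected to shift the number by no more than the usual scatter, with no clear direction. In this assay compound 3 is therefore estimated at 7500 nM, within a range from 2500 nM to 22000 nM. The implied step a 1.1-fold lower number from compound 1 to compound 3 (0.05 log units; within the scatter) is expected to stay within the scatter.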

Compound 3, half-maximal inhibitory concentration: 6410 nM
For compound 3 the middle estimate is 1.2-fold (0.07 log units) above the measured one, and the stated range covers the measured number.
By their numbers in this assay, from the lowest: compounds 3 and 1 (each within the scatter of the next); then compound 2.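

For the compounds shown here, with a 1.3-fold lower number from compound 1 to compound 3 (0.12 log units; within the scatter) in this assay, this is the first step that reads a single change, and it falls on an aromatic carbon para to a large group. At this position, going from 4-(trifluoromethyl)benzyl to 4-nitrobenzyl leaves the number within the scatter, so the two groups cannot be told apart on this read-out, even though nitro carries hydrogen-bond acceptors and trifluoromethyl carries none. Nothing measured for this pair offers a reason for this result.

Going by these compounds alone, whether an amine, a carboxylic acid or a longer chain at this same position would also stay within the scatter remains open, since trifluoromethyl and nitro are the only two groups compared here. As far as these compounds go, it is also open whether the same exchange would read alike on the core of compound 2.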